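Swapping a Propyl Chain for a Cyclobutyl Ring

The source may report more compounds than this note shows. Statements on the series, on what has been measured and on what is new or still open speak of the compounds shown alone.

Compound 1, `NS(=O)(=O)c1ccc(-c2nn(Cc3ccccc3F)c3ncccc23)o1`: in a functional assay (aorta) with Oryctolagus cuniculus as the target (on this read-out lower numbers stand for stronger inhibition and higher numbers for weaker inhibition), compound 1 gives 8000 nM.
Compound 2, `CCCc1cnc(-c2nn(Cc3ccccc3F)c3ncccc23)nc1N`: in this assay compound 2 gives 252000 nM.

Only these two compounds have been measured, and they share the same core while differing in the ring that hangs from it. Compound 2 has the higher of the two numbers, and compound 1 sits a long way lower; that gap lies well beyond the usual scatter of repeated measurements, so compound 2 is clearly the weaker inhibitor of the pair.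

Compound 3, `Nc1nc(-c2nn(Cc3ccccc3F)c3ncccc23)ncc1C1CCC1`, has not yet been measured. It keeps the core of compound 2 and makes a single change: cyclobutyl in place of propyl on an aromatic carbon. For the measured compounds named here, no pair of measured compounds differs in just this way, so there is no measured step to lean on. The two groups are of similar size and carry nothing that would be counted differently apart from the ring that closes, so the expectation is a step of a 1.6-fold lower number from compound 2 to compound 3 (0.20 log units; within the scatter) that stays within the scatter. Compound 3 is therefore estimated to give about 160000 nM, with a likely range from 40000 nM to 600000 nM.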

Compound 3, half-maximal inhibitory concentration: 633000 nM
The estimate for compound 3 lay 4.0-fold (0.60 log units) below the measured number; measured number above the stated range.
By their numbers in this assay, from the lowest: compound 1; then compound 2; then compound 3.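

In this assay the position on the aromatic carbon, ortho to an amino group, proves sensitive to the form of its carbon group: cyclobutyl in place of propyl gives a 2.5-fold higher number from compound 2 to compound 3 (0.40 log units; beyond the scatter) and so moves the compound toward weaker inhibition, a modest change but one that lies beyond the scatter. For the compounds shown here, until this pair, no step at this position could be read, whereas now a single group swap here is seen to shift the number, and of these two groups propyl gives the stronger inhibition. Nothing available on these compounds accounts for the step, so the reason for it remains unknown.

As far as these compounds go, with only propyl and cyclobutyl compared at this position, it remains open whether a shorter ethyl chain, a longer butyl chain, a smaller cyclopropyl ring or a polar group such as an amine would give a lower number. From the compounds shown here alone, it is also open whether the same swap would produce a step of similar size and direction on a compound carrying a different ring on the shared core.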